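The source may hold more compounds than are shown below. What is called first, only, known or untested is meant among the compounds shown, and "the series" means these compounds.

Compound 1, with the structure `Cc1n[nH]c(C(=O)O)c1Cc1cccc(C(F)(F)F)c1`, was examined in an assay on isolated protein for inhibition of 2-Hydroxyacid oxidase 2 (Homo sapiens), tested at 1 uM (on this read-out lower numbers stand for a weaker effect and higher numbers for a stronger effect at the one concentration tested), where compound 1 gives 5%. Two further compounds share its core. Compound 2, `Cc1n[nH]c(C(=O)O)c1Cc1cccc2ccccc12`, gives 22% in this assay, and compound 3, `Cc1n[nH]c(C(=O)O)c1Cc1ccc(-c2ccc(F)cc2)cc1`, gives 11%. Among these three numbers compound 1 stands at the low end: the value of compound 3 lies within the usual scatter of it, while the value of compound 2 lies beyond the scatter.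

Compound 4, `Cc1n[nH]c(C(=O)O)c1Cc1cccc(OC(F)(F)F)c1`, has not yet been measured. It differs from compound 1 in one place: trifluoromethoxy in place of trifluoromethyl on an aromatic carbon. Within the data shown here, no step between measured compounds bears on this change, so nothing in the data shows how far such a swap moves this read-out. With the low starting point of compound 1 at 5%, a step from compound 1 to compound 4 is expected to be small, as a number 3 percentage points higher from compound 1 to compound 4 (within the scatter), and not beyond the scatter. Compound 4 is therefore estimated at 8%, within a range from 0% to 25%.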

Compound 4, a percentage reported as inhibition, at one concentration (the size of the read-out at that concentration, not a potency): 2%
The estimate for compound 4 lay 6 percentage points above the measured number; the range from low to high includes it.
By their numbers in this assay, from the lowest: compounds 4, 1 and 3 (each within the scatter of the next); then compound 2.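

Among these compounds, the first step that isolates a single change shows that, on an aromatic carbon meta to a large group, trifluoromethoxy in place of trifluoromethyl gives a number 3 percentage points lower from compound 1 to compound 4 (within the scatter) in this assay and so cannot be told apart from no effect. The one hydrogen-bond acceptor that trifluoromethoxy adds therefore goes with no change that rises above the scatter at this position. Nothing measured here offers a reason for this result.

Still open, on these data alone, is whether a different group on this carbon, such as an amine, a nitrile or a carboxylic acid, would move the read-out beyond the scatter. Also open, as far as these compounds go, is whether the same swap would stay as small on a compound that starts from a higher read-out.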